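Bromo to methyl exchange across two substitution patterns

The source may hold more compounds than are shown below. What is called first, only, known or untested is meant among the compounds shown, and "the series" means these compounds.

Compound 1 `O=C1/C(=C/c2cccc(Br)c2)Cc2ccccc21` and compound 2 `O=C1/C(=C/c2ccc(Br)cc2)Cc2ccccc21` are built from the same atoms joined differently, and the difference between the two cores is not broken down here. In a functional assay on L1210 cells (Mus musculus) for inhibition (on this read-out higher numbers stand for weaker inhibition and lower numbers for stronger inhibition), compound 1 gives 43300 nM, and compound 2 gives 64800 nM. Compound 3 `Cc1cccc(/C=C2\Cc3ccccc3C2=O)c1` carries methyl in place of bromo on an aromatic carbon relative to compound 1, and the resulting step is a 1.2-fold higher number from compound 1 to compound 3 (0.07 log units; within the scatter). In this assay compound 3 gives 50400 nM, a number within the scatter of both compound 1 and compound 2. Compound 4 `Cc1ccc(/C=C2\Cc3ccccc3C2=O)cc1` has not yet been measured and carries methyl in place of bromo on an aromatic carbon relative to compound 2. The place differs from the earlier exchange: meta to a large group there, para to a large group here, so this is the same kind of change rather than the same one. Within the data shown here, the step from compound 2 to compound 4 is expected to be a 1.1-fold higher number from compound 2 to compound 4 (0.05 log units; within the scatter), resting on the single precedent a 1.2-fold higher number from compound 1 to compound 3 (0.07 log units; within the scatter) and carrying extra uncertainty from the different place. Compound 4 is therefore estimated at 72000 nM, with an expected range from 40000 nM to 130000 nM.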

Compound 4, half-maximal inhibitory concentration: 59100 nM
Compound 4: middle estimate off by 1.2-fold (0.09 log units), on the high side, and the stated range covers the measured number.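

Methyl in place of bromo on the core of compound 2, para to a large group, gives a 1.1-fold lower number from compound 2 to compound 4 (0.04 log units; within the scatter) in this assay. Set beside the earlier exchange, the new step agrees with it: the same change on two cores in this assay, a 1.2-fold higher number (0.07 log units; within the scatter) from compound 1 to compound 3 and a 1.1-fold lower number (0.04 log units; within the scatter) from compound 2 to compound 4, 1.3-fold (0.11 log units) apart, within the scatter of two such steps. So, in this series, the exchange leaves the read-out unchanged within the scatter on both cores, and a step of this kind carries from one to the other; this does not show that bromo and methyl can be swapped on any other core, and with only two small steps no direction of change can be read.

The compounds shown hold only bromo and methyl on this ring, so it remains open whether an amine, a carboxylic acid or a longer chain in the same place would leave the number as it stands. Also open, on these data alone, is whether the exchange would hold on a core altered elsewhere, since the two pairs share the same atoms apart from the place of the group.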